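From Closed Sulfur Ring to Open Chain

This account rests on a few compounds, and the source may have more. Where it says the series, first, only, none or still open, it means among the compounds named here.

Within the data shown here, in a functional assay on KB cells (Homo sapiens) for inhibition, read by MTT assay, with a stated time of 24 h, tested at 0.1 ug/mL (on this read-out lower numbers stand for less inhibition of growth and higher numbers for more inhibition of growth at the one concentration tested), compound 1 (`O=C(CCCCC1CCSS1)Nc1cccc(C(F)(F)F)c1`) gives 0.33% and is the only compound with a number so far. Compound 2 (`O=C(CCCCC1CCSS1)Nc1cccc2ccccc12`) has no single number: it is recorded as "not active" (no number reported) and so cannot be ranked on a scale. Compound 3 (`O=C(CCCCC(S)CCS)Nc1ccc(Br)cn1`) is the one further entry of this kind, also recorded as "not active" (no number reported) without a figure.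

Compound 4 (`O=C(CCCCC(S)CCS)Nc1cccc2ccccc12`) differs from compound 2 in one place, where a group of 5 heavy atoms (3 carbon, 2 sulfur; no ring) in place of a group of 5 heavy atoms (3 carbon, 2 sulfur; one five-membered non-aromatic ring with 2 hetero atoms), on a saturated chain carbon, four bonds along the chain from a carbonyl carbon is the change: the ring opens into the 1,3-disulfanylpropyl group. Among the measured compounds shown here, no measured pair shows this change on its own, so any expectation is loose. Compound 3 carries the same 1,3-disulfanylpropyl group and still reads "not active" (no number reported) in this assay although the rest of its structure differs. A step beyond the usual scatter is therefore not expected, and growth inhibition should stay close to nothing. Compound 4 is estimated at 2% with an expected range from 0% to 12% in this assay once it is measured.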

Compound 4, percent growth inhibition at one concentration: "not active" (no number reported)
Compound 4 has no reported number here, so the estimate cannot be set against anything.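

Compound 2 and compound 4 are both recorded as "not active" with no number, so no step can be read between them, and no evidence bears on this result. They leave open whether replacing the closed sulfur ring with the 1,3-disulfanylpropyl group changes growth inhibition at all.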